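The compounds below may be only part of what the source reports. "The series", "measured", "known", "first", "only" and "open" are said of these compounds alone.

Working notes on the series, values in a functional assay on HeLa cells (Homo sapiens) for antiproliferative activity, read by MTT assay, with a stated time of 24 h; on this read-out higher numbers stand for weaker inhibition and lower numbers for stronger inhibition:

- compound 1 `c1ccc(CSc2nnc(-c3ccc4c(c3)OCCO4)n2-c2ccccc2)cc1` gives 32800 nM
- compound 2 `Clc1ccccc1CSc1nnc(-c2ccc3c(c2)OCCO3)n1-c1ccccc1` gives 29000 nM
- compound 3 `Clc1cccc(CSc2nnc(-c3ccc4c(c3)OCCO4)n2-c2ccccc2)c1` gives 15000 nM

Compound 3 sits level with compound 2 within the scatter, and it stands apart only in a 2.2-fold lower number from compound 1 to compound 3 (0.34 log units; beyond the scatter) on this evidence. Next comes compound 4 `Cc1ccccc1CSc1nnc(-c2ccc3c(c2)OCCO3)n1-c1ccccc1`, with the change 2-methylphenyl in place of 3-chlorophenyl on a saturated chain carbon bound to a sulfur in the side chain. The closest evidence is a 1.9-fold lower number from compound 2 to compound 3 (0.29 log units; within the scatter) and, further back, a 1.1-fold lower number from compound 1 to compound 2 (0.05 log units; within the scatter) as well. Among the compounds with values here, no measured compound carries 2-methylphenyl. A small move toward a higher number in this assay is therefore expected, inside the scatter. The expected step is a 1.6-fold higher number from compound 3 to compound 4 (0.20 log units; within the scatter) on this reasoning. Compound 4 is estimated at 24000 nM with an expected range from 11000 nM to 50000 nM in this series.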

Compound 4, half-maximal inhibitory concentration: 36000 nM
Compound 4: middle estimate off by 1.5-fold (0.18 log units), on the low side, and the stated range covers the measured number.
By their numbers in this assay, from the lowest: compounds 3, 2, 1 and 4 (each within the scatter of the next, the first and the last beyond it).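

In this assay, the move from 3-chlorophenyl to 2-methylphenyl on the saturated chain carbon bound to a sulfur gives a step beyond the scatter (a 2.4-fold higher number from compound 3 to compound 4 (0.38 log units; beyond the scatter)). Methyl in place of chloro (a 1.2-fold higher number from compound 2 to compound 4 (0.09 log units; within the scatter)) and methyl in place of hydrogen (a 1.1-fold higher number from compound 1 to compound 4 (0.04 log units; within the scatter)) both stay within the scatter, so compound 4 sits level with compound 1 and compound 2, and only compound 3 stands apart from it. No measurement here bears on why this is so.

Open, on these data alone, is whether a methoxy group, an amine or a carboxylic acid in place of the chloro of compound 3 would hold its level. Also open, as far as these compounds go, is whether a methyl at that same place would do so.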